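The source may report more compounds than this note shows. Statements on the series, on what has been measured and on what is new or still open speak of the compounds shown alone.

Of the compounds shown here, three have been measured in a functional assay on UO-31 cells (Homo sapiens) for cytotoxicity, read by sulforhodamine B assay, with a stated time of 48 h; on this read-out higher numbers stand for weaker inhibition of growth and lower numbers for stronger inhibition of growth. Compound 1 `ClCc1cccc(Cn2cnc3ncnc(Cl)c32)c1` gives 1540 nM in this assay. Compound 2 `ClCc1ccc(Cn2cnc3nc(Cl)nc(Cl)c32)cc1` gives 1440 nM, and compound 3 `ClCc1cccc(Cn2cnc3nc(Cl)nc(Cl)c32)c1` gives 17400 nM. Compound 3 and compound 1 differ by hydrogen in place of chloro on an aromatic carbon, and this change makes a step of an 11-fold lower number from compound 3 to compound 1 (1.05 log units; beyond the scatter). The values of compound 1 and compound 2 lie within the scatter of each other, while compound 3 stands apart from both. The difference between the cores of compound 2 and compound 3 is not broken down here. Compound 4 `ClCc1ccc(Cn2cnc3ncnc(Cl)c32)cc1`, not yet measured, differs from compound 2 by hydrogen in place of chloro on an aromatic carbon, the same change that separates compound 3 from compound 1. Compound 2 gives 1440 nM, a number close to that of compound 1, so the second step is expected to be smaller than the earlier one. The step estimated here is a 3.2-fold lower number from compound 2 to compound 4 (0.51 log units; beyond the scatter). Compound 4 is therefore expected to give about 450 nM. Four of five repeat measurements of compound 4 are expected to fall between 120 nM and 1600 nM.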

Compound 4, concentration for 50% growth inhibition: 4780 nM
Estimate against measurement, compound 4: 11-fold (1.03 log units) below; measured number above the stated range.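

The change of hydrogen in place of chloro on an aromatic carbon does not behave alike on the two cores in this assay: the same change on two cores in this assay, an 11-fold lower number (1.05 log units; beyond the scatter) from compound 3 to compound 1 and a 3.3-fold higher number (0.52 log units; beyond the scatter) from compound 2 to compound 4, 38-fold (1.57 log units) apart, beyond the scatter of two such steps The new step, a 3.3-fold higher number from compound 2 to compound 4 (0.52 log units; beyond the scatter), runs against the earlier one, so the result of this change on one core could not be carried over to the other in this series. These two pairs show only that the outcome depends on the core; they do not show which difference between the cores is responsible, and they give no rule for any further core.

Whether the change would give a higher or a lower number on other cores remains open, since the compounds shown offer only these two pairs. Also open, from the compounds shown here alone, is what an amine, a methoxy group or a fluoro group would give on that same aromatic carbon between two ring nitrogen atoms, on either core.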